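The source may report more compounds than this note shows. Statements on the series, on what has been measured and on what is new or still open speak of the compounds shown alone.

The series shares one core, carried by compound 1 `CC#C[C@H]1CN(S(=O)(=O)c2ccc(N)nc2)CCN1c1ccc(C(C)(O)C(F)(F)F)nc1`, compound 2 `CC#C[C@H]1CN(S(=O)(=O)c2ccc(N)nc2)CCN1c1ccc(S(=O)(=O)Nc2ccccc2)cc1` and compound 3 `CC#C[C@H]1CN(S(=O)(=O)c2ccc(N)nc2)CCN1c1ccc(C(O)(C(F)(F)F)C(F)(F)F)cn1`, and differs only in the aromatic group on the piperazine nitrogen. In an assay on cells (Hepatocyte) for inhibition of glucokinase regulatory protein (Mus musculus), with stated times of 20 min and 40 min (a higher number here means that more compound is needed for the effect, a lower number that less compound is needed), compound 1 gives 1450 nM. In this assay compound 3 gives 421 nM. For compound 2 the assay reports only a limit, > 12500 nM, so its place on the scale is known solely as the limit of > 12500 nM in this assay, at which 1 of the 3 values shown sits; compound 1 and compound 3, which each carry a trifluoromethyl carbinol, both return numbers.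

Compound 4 `CC#C[C@H]1CN(S(=O)(=O)c2ccc(N)nc2)CCN1c1ccc([C@](O)(CO)C(F)(F)F)cc1` has not yet been measured in this assay. It differs from compound 2 in one place: 1,2-dihydroxy-1-(trifluoromethyl)ethyl in place of phenylsulfamoyl on an aromatic carbon. That change brings compound 4 closer to compound 1 and compound 3 in the kind of group it carries, even though its ring is the same six-membered aromatic ring of carbon only as in compound 2. A step of an at least 13-fold lower number from compound 2 to compound 4 (1.14 log units; beyond the scatter) toward a lower number is expected, beyond the scatter, with compound 4 estimated near 900 nM, within a range of 250 nM to 3500 nM.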

Compound 4, half-maximal effective concentration: 98 nM
For compound 4 the middle estimate is 9.2-fold (0.96 log units) above the measured one, and the stated range ends above it.
By their numbers in this assay, from the lowest: compound 4; then compound 3; then compound 1. At a limit, above all of these: compound 2.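

Within the data shown here, with 1,2-dihydroxy-1-(trifluoromethyl)ethyl in place of phenylsulfamoyl on this aromatic carbon, this assay gives an at least 120-fold lower number from compound 2 to compound 4 (2.10 log units; beyond the scatter), the first single-place step. It shows that the six-membered aromatic ring of carbon only does not by itself keep the value at a limit, and that the group on this carbon decides the reading. Compound 2 is held only by a limit, so the step has a lower bound and no exact size: the limit of > 12500 nM in this assay, at which 1 of the 4 values shown sits.

The compounds shown leave open which part of the new group carries the step: the terminal hydroxyl, the trifluoromethyl or the defined stereocentre. They also leave open how an amine or a carboxylic acid in place of that terminal hydroxyl would read on this ring.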